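A few compounds are considered here, and "the series" means these few. Any claim that something is new, unique, unknown or untested is made for them only; others in the source may bear on it.

Compound 1 `CCO[C@@H](CO)[C@H](O)C[S+]1C[C@@H](O)[C@H](O)[C@H]1CO` gives, in an assay for inhibition of Maltase-glucoamylase (Homo sapiens), using microsomes, with a stated time of 30 min (on this read-out higher numbers stand for weaker inhibition and lower numbers for stronger inhibition), 960 nM. Among the measured compounds shown here, compound 2 `CCCCCO[C@@H](CO)[C@H](O)C[S+]1C[C@@H](O)[C@H](O)[C@H]1CO` gives in this assay 1500 nM, which puts it at the top of the two numbers measured so far, though the step of a 1.6-fold higher number from compound 1 to compound 2 (0.19 log units; within the scatter) is within the scatter, so the two compounds cannot be told apart on this read-out. Compound 3 `CCCCCCCO[C@@H](CO)[C@H](O)C[S+]1C[C@@H](O)[C@H](O)[C@H]1CO` has not yet been measured. Set against compound 2 it shows (ethyl in place of hydrogen on a saturated chain carbon, five bonds along the chain from an oxygen on a saturated carbon), the same kind of lengthening of the chain that distinguishes compound 2 from compound 1. That single earlier step is the only measured one that bears on the change, and it was small: a 1.6-fold higher number from compound 1 to compound 2 (0.19 log units; within the scatter). On that basis the step from compound 2 to compound 3 is expected to be small as well, in this assay perhaps a somewhat higher number, but nothing that can be separated from the scatter with confidence. The estimate for compound 3 is therefore 2000 nM, with a range from 700 nM to 6000 nM, which means an expected step of a 1.3-fold higher number from compound 2 to compound 3 (0.12 log units; within the scatter).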

Compound 3, half-maximal inhibitory concentration: 640 nM
Estimate against measurement, compound 3: 3.1-fold (0.49 log units) above; measured number outside the range, below it.
By their numbers in this assay, from the lowest: compounds 3, 1 and 2 (each within the scatter of the next, the first and the last beyond it).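

In this assay, among the compounds shown here, ethyl in place of hydrogen on a saturated chain carbon, five bonds along the chain from an oxygen on a saturated carbon, gives the first step on this chain that lies beyond the scatter, a 2.3-fold lower number from compound 2 to compound 3 (0.37 log units; beyond the scatter), whereas the earlier lengthening, a 1.6-fold higher number from compound 1 to compound 2 (0.19 log units; within the scatter), could not be told from the scatter. The longest chain still cannot be separated from the shortest: the step is a 1.5-fold lower number from compound 1 to compound 3 (0.18 log units; within the scatter), so chain length does not follow a steady trend across these three compounds, and the whole lengthening leaves the read-out about where it began. Nothing given here accounts for the modest step from the pentyl-bearing compound to the heptyl-bearing one.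

Going by these compounds, it remains open whether a longer chain than that of compound 3 would move the number further down or send it back up. On these data alone, it is also open whether the step depends on an all-carbon chain, which a chain ending in an amine or a carboxylic acid would test.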